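This account rests on a few compounds, and the source may have more. Where it says the series, first, only, none or still open, it means among the compounds named here.

Compound 1 `CC(C)(C)N(NC(=O)c1ccccc1F)C(=O)c1ccccc1Cl` is the most potent of the compounds with a numerical value here: in an assay on cells for agonist activity at ecdysone receptor (Bombyx mori), read by a luciferase reporter, with a stated time of 24 h (a lower number here means that less compound is needed, a higher number that more compound is needed for the effect), compound 1 gives 51.3 nM, the lowest of the two numbers shown. Compound 2 `CC(C)(C)N(NC(=O)c1ccccc1)C(=O)C1CCCCC1`, which carries a saturated ring on one carbonyl, gives 46800 nM in this assay, a gap far beyond the scatter. Compound 3 `Cc1cc(C)cc(C(=O)NN(C(=O)CCCC(C)C)C(C)(C)C)c1`, with a branched chain on one carbonyl, reaches only the limit of this assay at > 100000 nM; this is a limit of the assay and not a number (the limit of > 100000 nM in this assay, at which 1 of the 3 values shown sits).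

Compound 4 `CCCCCCC(=O)NN(C(=O)c1ccccc1Cl)C(C)(C)C` has not been measured. It differs from compound 1 in one place (hexyl in place of 2-fluorophenyl on a carbonyl carbon), so that one aromatic ring of compound 1 is traded for a chain, as happened in compound 2 and compound 3, both of which sit at very high numbers. Because compound 2 gives 46800 nM, the step of a 580-fold higher number from compound 1 to compound 4 (2.77 log units; beyond the scatter) is expected to be large and upward, toward a much higher number. Compound 4 is therefore estimated at 30000 nM in this assay, within a range from 5000 nM to 100000 nM.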

Compound 4, half-maximal effective concentration: 741 nM
For compound 4 the middle estimate is 40-fold (1.61 log units) above the measured one; measured number outside the range, below it.
By their numbers in this assay, from the lowest: compound 1; then compound 4; then compound 2. At a limit, above all of these: compound 3.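

Going by these compounds alone, the first pair that differs in one place shows that, on this carbonyl carbon, hexyl in place of 2-fluorophenyl gives a 14-fold higher number from compound 1 to compound 4 (1.16 log units; beyond the scatter) in this assay. The aromatic ring at this place therefore matters, yet it is not indispensable: with only a chain there, compound 4 still gives a numerical value of 741 nM and not a limit. Nothing shown here gives a reason for the size of this step.

The compounds shown leave open whether the loss follows the ring itself or its fluorine, which a plain phenyl at this place would separate. They also leave open how the number moves with a butyl or octyl chain in place of hexyl, or with a cyclohexyl ring on this same carbonyl carbon.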